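A few compounds are considered here, and "the series" means these few. Any claim that something is new, unique, unknown or untested is made for them only; others in the source may bear on it.

The compounds share the core of compound 1 `COC(=O)/C=C/c1cccc(N(Cc2ccc(/C=C/c3scnc3C)cc2)C(=O)C2CCCCC2)c1`, which in an assay on isolated protein with Bile acid receptor (Homo sapiens) as the target (on this read-out lower numbers stand for an effect already at smaller amounts and higher numbers for an effect only at larger amounts of compound), gives 227 nM. Within the data shown here, compound 2 `COC(=O)/C=C/c1cccc(N(Cc2ccc(/C=C/c3scnc3C)cc2)C(=O)C(C)C)c1` carries an isopropyl in place of the cyclohexyl on the carbonyl carbon and in this assay gives 228 nM; the step of a 1.0-fold higher number from compound 1 to compound 2 (0.00 log units; within the scatter) lies within the scatter, so the two compounds sit at the same level, and compound 2 stands on a par with the one other numbered value. Compound 3 `COC(=O)/C=C/c1cccc(N(Cc2ccc(/C=C/C(=O)OC(C)(C)C)cc2OC)C(=O)C2CCCCC2)c1` is reported in this assay only as a limit, > 1000 nM, and the limit of > 1000 nM in this assay, at which 1 of the 3 values shown sits, marks that entry. Compound 4 `COC(=O)/C=C/c1cccc(N(Cc2ccc(-c3ccc(F)c(Cl)c3)cc2)C(=O)C(C)C)c1` has not yet been measured. It differs from compound 2 by 3-chloro-4-fluorophenyl in place of 2-(4-methyl-1,3-thiazol-5-yl)ethenyl on an aromatic carbon. Among the measured compounds shown here, no measured step touches this part of the molecule: the only step on record, a 1.0-fold higher number from compound 1 to compound 2 (0.00 log units; within the scatter), concerns the group on the carbonyl carbon, and compound 3 differs from compound 1 in two places at once, so it yields no single step to lean on. The expectation therefore rests on the level of compound 2 alone, with wide uncertainty in both directions. Compound 4 is expected to give 400 nM in this assay, within 100 nM to 2000 nM. This corresponds to an expected step of a 1.8-fold higher number from compound 2 to compound 4 (0.24 log units; within the scatter).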

Compound 4, half-maximal effective concentration: 129 nM
The estimate for compound 4 lay 3.1-fold (0.49 log units) above the measured number, and the stated range covers the measured number.
By their numbers in this assay, from the lowest: compounds 4, 1 and 2 (each within the scatter of the next). At a limit, above all of these: compound 3.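

In this assay, among these compounds, this is the first reading of a change at the aromatic carbon para to a large group, on the six-membered aromatic ring of carbon only, and the exchange of whole groups gives a 1.8-fold lower number from compound 2 to compound 4 (0.25 log units; within the scatter), so compound 2 and compound 4 sit at the same level. This pair shows that the level does not depend on the five-membered aromatic ring with its 2 hetero atoms, on the double bond outside aromatic rings or on the 2 hydrogen-bond acceptors of the group that leaves, since a 3-chloro-4-fluorophenyl with 0 hydrogen-bond acceptors takes its place without a change beyond the scatter. The data shown offer no measured basis for explaining how the two groups come to match here.

As far as these compounds go, what stays open is whether this aromatic carbon keeps the level when it carries a different kind of group, such as an aminomethyl group or a carboxylic acid. From the compounds shown here alone, it is also open whether a carboxylic acid in place of the methyl ester holds the level, and whether the 3-chloro-4-fluorophenyl group behaves the same way with a cyclohexyl on the carbonyl carbon.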